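A few compounds are considered here, and "the series" means these few. Any claim that something is new, unique, unknown or untested is made for them only; others in the source may bear on it.

Measured compounds:
- compound 1, `CCC(C(=O)N1CCN(c2cccc(Cl)c2)CC1)N1C(=O)CCC1=O`: 0%
- compound 2, `CCC(C(=O)N1CCN(c2ccccc2F)CC1)N1C(=O)CCC1=O`: 0%
- compound 3, `CC(C(=O)N1CCN(c2cccc(Cl)c2)CC1)N1C(=O)CCC1=O`: 50%

In a functional assay on the whole organism (strain Swiss) with Mus musculus as the target, in the maximal electroshock model, with a stated time of 1 h, at a dose of 100 mg/kg by the intraperitoneal route (on this read-out higher numbers stand for a stronger effect at the one dose given and lower numbers for a weaker effect), compound 2 gives 0%, level with compound 1 at the digits shown, and together these two give the lowest of the three numbers. Among the measured compounds shown here, compound 3 stands a number 50 percentage points higher from compound 1 to compound 3 (beyond the scatter), the one large step in the set. That step goes with a change on the saturated chain, not on the aromatic ring.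

Compound 4, `CCC(C(=O)N1CCN(c2ccccc2)CC1)N1C(=O)CCC1=O`, has not yet been tested. It differs from compound 2 only in that (hydrogen in place of fluoro on an aromatic carbon). The step that bears on a change at the aromatic ring is no change at the digits printed from compound 1 to compound 2 (within the scatter), where one substituted phenyl replaced another and the read-out stayed where it was. The large chain step from compound 1 to compound 3 does not apply here, since compound 4 keeps the ethyl chain of compounds 1 and 2. Compound 4 is therefore expected to stay close to compound 2, with a number 5 percentage points higher from compound 2 to compound 4 (within the scatter) as the expected step in this assay. The estimate for compound 4 is 5%, within 0% to 25%.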

Compound 4, a percentage reported as activity, at one dose (the size of the read-out at that dose, not a potency): 0%
Beside the measured number, compound 4's estimate is 5 percentage points above it; low and high end bracket the measured number.
By their numbers in this assay, from the lowest: compounds 1, 2 and 4 (each within the scatter of the next); then compound 3.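

In this assay, hydrogen in place of fluoro on the aromatic carbon gives no change at the digits printed from compound 2 to compound 4 (within the scatter), and hydrogen in place of chloro gives no change at the digits printed from compound 1 to compound 4 (within the scatter). Among the compounds shown here, the earlier compounds compared only one halogen-bearing phenyl ring with another, whereas these steps add the plain phenyl ring and show that, with the ethyl chain kept, neither halogen sets its compound apart from compound 4 at this one dose. Nothing measured here offers an explanation for this flat result.

As far as these compounds go, whether a methoxy group or an amine on the aromatic ring would raise the read-out on the ethyl chain stays open. So does whether the plain phenyl or 2-fluorophenyl ring would hold the level of compound 3 on its shorter chain.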